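Working notes: diethylamino to 4-methylpiperazin-1-yl

The source may report more compounds than this note shows. Statements on the series, on what has been measured and on what is new or still open speak of the compounds shown alone.

Measured in a functional assay on HepG2 cells (Homo sapiens) for antiproliferative activity, read by MTT assay, with a stated time of 72 h; on this read-out lower numbers stand for stronger inhibition and higher numbers for weaker inhibition:
- compound 1 `O=C(N/N=C/c1cccc(Cl)c1Cl)Nc1ccc(Oc2ccnc3[nH]ccc23)cc1`: "not active" (no number reported)
- compound 2 `CCN(CC)CCCn1cccc1/C=N/NC(=O)Nc1ccc(Oc2ccnc3[nH]ccc23)c(F)c1`: 2140 nM

In this assay, among the compounds with values here, compound 2 holds the only number so far, 2140 nM, while compound 1 is recorded as "not active" (no number reported) and gives no figure to compare. The next compound is compound 3 `CN1CCN(CCCn2cccc2/C=N/NC(=O)Nc2ccc(Oc3ccnc4[nH]ccc34)c(F)c2)CC1`, which carries 4-methylpiperazin-1-yl in place of diethylamino on a saturated chain carbon, three bonds along the chain from an aromatic nitrogen. Within the data shown here, no measured pair shows the effect of this kind of change, so the expectation rests on compound 2 at 2140 nM alone, and no direction can be argued from the data. The expected step is a 1.2-fold higher number from compound 2 to compound 3 (0.07 log units; within the scatter), which would be none beyond the usual scatter in this assay. For compound 3 the estimated value is 2500 nM, with an expected range of 800 nM to 8000 nM.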

Compound 3, half-maximal inhibitory concentration: 2740 nM
The estimate for compound 3 lay 1.1-fold (0.04 log units) below the measured number, within the range that was stated.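

In this assay, within the data shown here, the exchange of diethylamino for 4-methylpiperazin-1-yl on a saturated chain carbon, three bonds along the chain from an aromatic nitrogen, gives a 1.3-fold higher number from compound 2 to compound 3 (0.11 log units; within the scatter) and is the first step that can be read. At this position, a six-membered non-aromatic ring with 2 hetero atoms can therefore stand in place of the open diethylamino group with no difference beyond the usual scatter. No measured property bears on this result, so no reason for it can be offered.

On these data alone, it remains open whether morpholin-4-yl, a carboxylic acid or a longer chain in place of 3-(diethylamino)propyl would move the number beyond the scatter. Compound 1 differs from the others in more than one place and has no number, so the contribution of the side chain as a whole cannot be read.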